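Methyl added to the shared core of compound 1

The source may hold more compounds than are shown below. What is called first, only, known or untested is meant among the compounds shown, and "the series" means these compounds.

Among the compounds with values here, compound 1 `COCc1cc(OC)c(-c2csc3c(N(CC4CCOCC4)CC4CC4)c(C)nn23)c(OC)c1` gives 46 nM in an assay on HEK293 cells for displacement of a labelled ligand from corticotropin-releasing factor receptor 1 (Homo sapiens), read by scintillation proximity assay, with a stated time of 2 h (on this read-out higher numbers stand for weaker inhibition and lower numbers for stronger inhibition), the lowest of the two numbers so far in hand. Compound 2 `COCc1cc(OC)c(-c2csc3c(N(CC4CCOCC4)CC4CC4)c(OC)nn23)c(OC)c1`, which carries methoxy in place of methyl on an aromatic carbon, gives 69 nM in this assay; the step of a 1.5-fold higher number from compound 1 to compound 2 (0.18 log units; within the scatter) stays within the scatter, so the two values cannot be ordered.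

Compound 3 `COCc1cc(OC)c(-c2c(C)sc3c(N(CC4CCOCC4)CC4CC4)c(C)nn23)c(OC)c1` remains to be measured. It differs from compound 1 by methyl in place of hydrogen on an aromatic carbon. Within the data shown here, no measured step touches this carbon of the shared core: the single step in hand, a 1.5-fold higher number from compound 1 to compound 2 (0.18 log units; within the scatter), concerns another aromatic carbon and was itself within the scatter. There is therefore nothing in the series that points to a shift in either direction at this site, and the working assumption is that the added methyl leaves the number close to where compound 1 stands. The step expected, a 1.1-fold higher number from compound 1 to compound 3 (0.04 log units; within the scatter), is no larger than the scatter. On this basis compound 3 is expected at 50 nM, with a range from 15 nM to 160 nM in this assay.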

Compound 3, half-maximal inhibitory concentration: 76 nM
Compound 3: middle estimate off by 1.5-fold (0.18 log units), on the low side; the range from low to high includes it.
By their numbers in this assay, from the lowest: compounds 1, 2 and 3 (each within the scatter of the next).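

Methyl in place of hydrogen on the aromatic carbon next to the ring sulfur, in this assay, gives a 1.7-fold higher number from compound 1 to compound 3 (0.22 log units; within the scatter), so this carbon of the shared core accepts the added methyl with no step that can be told from the scatter. Within the data shown here, this is the first reading at this carbon, as the earlier step, a 1.5-fold higher number from compound 1 to compound 2 (0.18 log units; within the scatter), concerns another aromatic carbon, and neither step lies beyond the scatter. Nothing in hand bears on why the number lands where it does at this carbon.

Whether a longer chain, an amine or a carboxylic acid on this same carbon would give a step beyond the scatter remains open, as the compounds shown hold only hydrogen and methyl here. Also open is whether methyl on this carbon would give a similar step when methoxy replaces methyl on the other aromatic carbon, as in compound 2, since the compounds shown do not combine the two changes.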